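Amide in place of oxazolylamine on the core of compound 1

This account rests on a few compounds, and the source may have more. Where it says the series, first, only, none or still open, it means among the compounds named here.

Compound 1 `CN(c1ncco1)c1cnc(NCc2c(F)ccc3c2CCO3)n2cnnc12` is the reference for this step. Within the data shown here, in an ADME assay on microsomes from liver (Homo sapiens) for metabolic stability, read by LC-MS, using NADPH, with stated times of 5 min and 30 min, tested at 1 uM (on this read-out lower numbers stand for slow clearance and higher numbers for fast clearance), compound 1 gives 11 mL.min-1.g-1, the lowest of the three numbers known so far. Compound 3 `Cc1cc(-c2cnc(NCc3c(F)ccc4c3CCO4)c3cn[nH]c(=O)c23)n(C)n1` gives 24 mL.min-1.g-1 in this assay, and compound 2 `CC(=O)N1CCC(c2cnc(NCc3c(F)ccc4c3CCO4)c3cn[nH]c(=O)c23)CC1` gives 207 mL.min-1.g-1, the highest of the three. Among the measured compounds shown here, the only single-point step known, an 8.6-fold lower number from compound 2 to compound 3 (0.94 log units; beyond the scatter), swaps a group at another place on a different core, so it bears on the present change only as a sense of how far one group exchange can move this read-out. Compound 4 `O=C(Nc1cnc(NCc2c(F)ccc3c2CCO3)n2cnnc12)c1ccccc1` differs from compound 1 as follows: benzamido in place of methyl(1,3-oxazol-2-yl)amino on an aromatic carbon. For the measured compounds named here, no known step exchanges this group, so neither direction nor size is fixed by the data, and the expectation is drawn wide. A step of a 2.0-fold higher number from compound 1 to compound 4 (0.30 log units; within the scatter) is expected, leaning toward a higher number than compound 1 but possibly staying within the scatter. For compound 4 the expected value in this assay is 22 mL.min-1.g-1, within a range of 7 mL.min-1.g-1 to 70 mL.min-1.g-1.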

Compound 4, intrinsic clearance in microsomes: 10 mL.min-1.g-1
Compound 4: middle estimate off by 2.2-fold (0.34 log units), on the high side, and the stated range covers the measured number.
By their numbers in this assay, from the lowest: compounds 4 and 1 (each within the scatter of the next); then compound 3; then compound 2.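

In this assay the swap of methyl(1,3-oxazol-2-yl)amino for benzamido on this aromatic carbon gives a 1.1-fold lower number from compound 1 to compound 4 (0.04 log units; within the scatter) and so leaves the read-out within the scatter. At this position on the shared core, a six-membered aromatic ring of carbon only and an amide hydrogen thus read the same as the five-membered aromatic ring with 2 hetero atoms, so for these two compounds the number does not depend on the oxazole ring. No measurement available here accounts for the two groups reading alike.

Open, as far as these compounds go, is whether a plain amine or a short acetamido at this carbon would read the same, or whether the aromatic ring of the benzamido is needed. Also open, from the compounds shown here alone, is how a carboxylic acid or a dimethylamino group on that ring would read.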